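The source may hold more compounds than are shown below. What is called first, only, known or untested is meant among the compounds shown, and "the series" means these compounds.

Measured compounds:
compound 1, `COc1cc2c(cc1OC)CN(S(=O)(=O)c1ccc(-n3cc(COc4ccc([N+](=O)[O-])cc4)nn3)cc1)CC2`: > 50 ug/mL
compound 2, `O=S(=O)(c1ccc(-n2cc(COc3ccccc3)nn2)cc1)N1CCc2ccccc2C1`: > 50 ug/mL

In an ADME assay on Vero cells (Chlorocebus sabaeus) for cytotoxicity, with a stated time of 4 days (a higher number here means a weaker inhibitor, a lower number a stronger inhibitor), compound 1 gives > 50 ug/mL, which is a limit of the assay and not a number. Compound 2 likewise gives a limit, > 50 ug/mL. Compound 1 thus stands at the limit of > 50 ug/mL in this assay, at which 2 of the 2 values shown sit. Compound 3 `COc1cc2c(cc1OC)CN(S(=O)(=O)c1ccc(-n3cc(COc4ccccc4C)nn3)cc1)CC2` differs from compound 1 by 2-methylphenyl in place of 4-nitrophenyl on an oxygen on a saturated carbon. Among the compounds with values here, no step between measured compounds is known, so the estimated step that the limit leaves unreadable from compound 1 to compound 3 in this assay is expected to be none beyond the scatter. Compound 3 is expected to give 60 ug/mL, between 30 ug/mL and 150 ug/mL, most likely again as a limit.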

Compound 3, half-maximal inhibitory concentration: > 50 ug/mL
Compound 3 gave a limit, no number; the forecaster's own chance of this, stated with the estimate: 85%; the middle value is on the limit's open side.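

In this assay, within the data shown here, compound 1 and compound 3 both give limits and not numbers, so no step between them can be read. Whether this assay would show any real difference among the compounds shown remains open.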